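Removing the side group from compound 1

A few compounds are considered here, and "the series" means these few. Any claim that something is new, unique, unknown or untested is made for them only; others in the source may bear on it.

Compound 1 `CC(C)(O)C(CCC/C=C(\c1ccccc1)c1cccnc1)C(=O)O`: 42 nM
Compound 2 `CC(C)CSC(CCC/C=C(\c1ccccc1)c1cccnc1)C(=O)O`: 110 nM
Compound 3 `O=C(O)C(CCC/C=C(\c1ccccc1)c1cccnc1)Sc1ccccc1`: 33 nM

In an assay (Equus caballus) for inhibition of Thromboxane-A synthase (Homo sapiens), using microsomes (a lower number here means a stronger inhibitor, a higher number a weaker inhibitor), compound 1 stands second highest of the three numbers: compound 3 is nearest, with a 1.3-fold lower number from compound 1 to compound 3 (0.10 log units; within the scatter), and compound 2 is furthest, with a 2.6-fold higher number from compound 1 to compound 2 (0.42 log units; beyond the scatter). Compound 4 `O=C(O)CCC/C=C(\c1ccccc1)c1cccnc1` differs from compound 1 in one place: carboxy in place of 1-carboxy-2-hydroxy-2-methylpropyl on a saturated chain carbon, three bonds along the chain from a double-bonded chain carbon. The measured steps only exchange the group at that chain carbon, as in a 3.3-fold lower number from compound 2 to compound 3 (0.52 log units; beyond the scatter), and every such exchange was modest. On these data alone, none removes the group entirely, so the change in compound 4 is untested. A modest weakening is therefore expected, a 2.4-fold higher number from compound 1 to compound 4 (0.38 log units; beyond the scatter). Compound 4 is estimated at 100 nM, with a range from 30 nM to 400 nM.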

Compound 4, half-maximal inhibitory concentration: 30 nM
Estimate against measurement, compound 4: 3.3-fold (0.52 log units) above; measured number inside the range.
By their numbers in this assay, from the lowest: compounds 4, 3 and 1 (each within the scatter of the next); then compound 2.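

Removing the 1-hydroxy-1-methylethyl group altogether leaves inhibition effectively unchanged (a 1.4-fold lower number from compound 1 to compound 4 (0.15 log units; within the scatter)). The side group of compound 1 is therefore not required at this saturated chain carbon, and the plain chain ending in carboxy in compound 4 performs as well within the scatter. No evidence here explains this result.

Still open, on these data alone, is whether an amine or a longer chain at this carbon would match compound 4 or shift its number. Also open, as far as these compounds go, is how an amide in place of the carboxy would behave.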